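The compounds below may be only part of what the source reports. "The series", "measured", "known", "first", "only" and "open" are said of these compounds alone.

In a functional assay on HCT-116 cells (Homo sapiens) for cytotoxicity, read by sulforhodamine B assay, with a stated time of 48 h (a lower number here means a stronger inhibitor, a higher number a weaker inhibitor), compound 1 (`O=C(Nc1nn(C(=O)c2ccccc2)c2c1CN(C(=O)c1ccccc1)C2)c1ccc(F)cc1`) gives 2780 nM and compound 2 (`CC(=O)n1nc(NC(=O)c2ccccc2)c2c1CN(C(=O)c1cccc([N+](=O)[O-])c1)C2`) gives 17300 nM as the higher of the two numbers, a gap beyond the scatter. Compound 3 (`CC(=O)n1nc(NC(=O)c2ccccc2)c2c1CN(C(=O)N(C)C)C2`) carries dimethylamino in place of 3-nitrophenyl on a carbonyl carbon of compound 2 (dimethylamino in place of 3-nitrophenyl on a carbonyl carbon). Among the measured compounds shown here, no measured step covers this change, so no shift beyond the scatter is expected, and the estimated step is a 1.0-fold higher number from compound 2 to compound 3 (0.02 log units; within the scatter) for now. In this assay compound 3 is expected at 18000 nM (estimated range 6000 nM to 50000 nM).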

Compound 3, half-maximal inhibitory concentration: 70300 nM
Beside the measured number, compound 3's estimate is 3.9-fold (0.59 log units) below it, outside the stated range (above it).
By their numbers in this assay, from the lowest: compound 1; then compound 2; then compound 3.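

Exchanging 3-nitrophenyl for dimethylamino on a carbonyl carbon whose other neighbour is an amide-type nitrogen in a ring gives in this assay a 4.1-fold higher number from compound 2 to compound 3 (0.61 log units; beyond the scatter). Among the compounds shown here, this is the first measured step at this position, and it shows that the group here affects the read-out, with the number rising on loss of the aromatic ring. Nothing measured explains the shift.

The compounds shown leave open whether the ring itself or its nitro group matters more. A cyclohexyl or piperidine group on this carbonyl carbon would bear on that question.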